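A few compounds are considered here, and "the series" means these few. Any claim that something is new, unique, unknown or untested is made for them only; others in the source may bear on it.

Of the compounds shown here, three have so far been measured in a functional assay on the whole organism with Mus musculus as the target; a higher number here means a larger maximal response, a lower number a smaller maximal response. Compound 1 `C=CCn1c(=O)n(C2C[C@H](O)C(CO)O2)c2nc(N)nc(O)c21` reaches 131% in this assay. Compound 3 `CCn1c(=O)n(C2OC(CO)[C@@H](O)[C@H]2O)c2nc(N)nc(O)c21` reaches 82%. Compound 2 `C=CCn1c(=O)n(CCCC)c2nc(N)nc(O)c21` reaches 36%, the lowest of the three numbers; the nearest to it is compound 3, whose number lies higher by more than the usual scatter, and the furthest is compound 1, higher still. No two of these three differ in only one place, so no single step can be read from them.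

Compound 4 `C=CCn1c(=O)n(CCCCO)c2nc(N)nc(O)c21` has not yet been measured. It differs from compound 2 in one place: hydroxy in place of hydrogen on a saturated chain carbon, four bonds along the chain from an aromatic nitrogen. Among the compounds with values here, nothing measured so far isolates this change. Still, a rise is expected for compound 4 because compound 1 gives 131% and compound 3 gives 82%, both carrying hydroxy groups, while compound 2 carries none. The step from compound 2 to compound 4 is expected to be moderate and upward, a number 19 percentage points higher from compound 2 to compound 4 (beyond the scatter). Compound 4 is estimated to reach 55%, between 30% and 90%.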

Compound 4, largest response reached (reported as maximal response), in percent of the reference or control that the assay uses: 16%
Beside the measured number, compound 4's estimate is 39 percentage points above it; measured number below the stated range.
By their numbers in this assay, from the lowest: compound 4; then compound 2; then compound 3; then compound 1.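

In this assay, within the data shown here, the swap of hydroxy for hydrogen on a saturated chain carbon, four bonds along the chain from an aromatic nitrogen, gives a number 20 percentage points lower from compound 2 to compound 4 (beyond the scatter) and is the first single change that can be read in this set. On this chain, then, adding a hydroxy group lowers the maximal response rather than raising it, so a hydroxy group alone does not account for the higher numbers of compound 1 and compound 3, which each differ from compound 2 in more than one place. No measurement shown explains this fall.

As far as these compounds go, whether the fall follows the hydroxy group or this place on the chain remains open. A methoxy group or an amine at the same carbon, or a longer chain ending in hydroxy, could help separate the two.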